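The source may report more compounds than this note shows. Statements on the series, on what has been measured and on what is new or still open speak of the compounds shown alone.

Working notes on a small series built on one shared core. Compound 1 `O=C1CSC(c2c(Cl)cccc2Cl)N1CCN1CCCCC1` and compound 2 `O=C1CSC(c2ccc([N+](=O)[O-])cc2)N1CCN1CCCCC1` have both been run in an ADME assay on Vero cells (Chlorocebus sabaeus) for cytotoxicity, read by neutral red uptake, tested at 25 ug/mL; a lower number here means a stronger effect, a higher number a weaker effect of the compound at the concentration tested. In this assay compound 1 gives 100%. In this assay compound 2 gives 100%, level with compound 1 at the digits reported; the two lie within the scatter of each other, so no order between them can be claimed. Compound 2 thus stands where compound 1 stands, at the end of the scale that means a weaker effect at the concentration tested.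

The next compound, compound 3 `O=C1CSC(c2ccc(Cl)cc2)N1CCN1CCCCC1`, has not yet been run. It differs from compound 2 in one place: chloro in place of nitro on an aromatic carbon. Among the compounds with values here, no step between measured compounds is available to size this change. Because compound 1 gives 100% and compound 2 gives 100% despite carrying different groups on the shared core, the step of no change at the digits printed from compound 2 to compound 3 (within the scatter) is expected to be none beyond the scatter. Compound 3 is estimated at 100% in this assay, with a range from 90% to 100%.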

Compound 3, a percentage reported as activity, at one concentration (the size of the read-out at that concentration, not a potency): 84%
Compound 3: the middle estimate sits 16 percentage points above what was measured, outside the stated range (below it).
By their numbers in this assay, from the lowest: compound 3; then compounds 1 and 2 (each within the scatter of the next).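

In this assay the aromatic carbon para to a large group turns out not to be silent: chloro in place of nitro there gives a number 16 percentage points lower from compound 2 to compound 3 (beyond the scatter) and is a modest step, beyond the scatter. Compound 1 and compound 2 had stood level despite their different groups, so they gave no readable step, whereas this single change now shows that the read-out can move with what sits on this carbon. Nothing available bears on why this step occurs.

The compounds shown leave open whether the step goes with the arrival of chloro or with the departure of nitro. A fluoro, a methoxy or an amine on the same aromatic carbon would bear on that question and would show how far the read-out moves with other groups.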